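Methoxy in Place of Methylamino on the Shared Core

The source may report more compounds than this note shows. Statements on the series, on what has been measured and on what is new or still open speak of the compounds shown alone.

Measured so far:
Compound 1, `O=C(Nc1ccc(-n2ncc3c(Cl)cccc32)cc1)Nc1ccc(Cl)c(C(F)(F)F)c1`: 3600 nM
Compound 2, `CNc1cccc2c1cnn2-c1ccc(NC(=O)Nc2ccc(Cl)c(C(F)(F)F)c2)cc1`: 6300 nM

Both compounds were tested in a functional assay on LoVo cells (Homo sapiens) for cytotoxicity, read by MTT assay, with a stated time of 72 h; on this read-out higher numbers stand for weaker inhibition and lower numbers for stronger inhibition. For the measured compounds named here, compound 2 holds the higher of the two numbers, but the only step that reaches it, a 1.8-fold higher number from compound 1 to compound 2 (0.24 log units; within the scatter), lies within the scatter, so compound 1 and compound 2 cannot be told apart on these data.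

Compound 3, `COc1cccc2c1cnn2-c1ccc(NC(=O)Nc2ccc(Cl)c(C(F)(F)F)c2)cc1`, has not yet been measured in this assay. It differs from compound 2 in one place: methoxy in place of methylamino on an aromatic carbon. Going by the values given here, the only step measured so far changed the same spot of the shared core, from chloro to methylamino, and produced nothing beyond the scatter. Among the compounds with values here, no measurement here shows how a methoxy group at this spot behaves, but the one comparison available gives no sign that this part of the molecule moves the numbers much. A step of about a 1.3-fold lower number from compound 2 to compound 3 (0.10 log units; within the scatter) is therefore expected, which is to say none beyond the scatter. Compound 3 is estimated at 5000 nM, with a likely range from 2000 nM to 13000 nM.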

Compound 3, half-maximal inhibitory concentration: > 32000 nM
Compound 3 gave a limit, no number; the forecaster's own chance of this, stated with the estimate: 10%; middle value at least 6.4-fold (0.80 log units) away from the limit.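

In this assay, the reading for compound 3 is a limit of the assay and not a number, and it is the only compound shown that sits at this limit: the limit of > 32000 nM in this assay, at which 1 of the 3 values shown sits. This spot on the shared core now proves able to shift the read-out, which the earlier comparison gave no sign of: the exchange of methylamino for methoxy gives an at least 5.0-fold higher number from compound 2 to compound 3 (0.70 log units; beyond the scatter), whereas the earlier exchange gave only a 1.8-fold higher number from compound 1 to compound 2 (0.24 log units; within the scatter). Methoxy also separates from chloro, with an at least 8.8-fold higher number from compound 1 to compound 3 (0.94 log units; beyond the scatter), so among these three groups on this aromatic carbon, methoxy alone stands apart from the other two, which cannot be told apart from each other.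

What the compounds shown leave open is which part of the exchange matters, since methylamino carries 1 hydrogen-bond donor and methoxy 0, and the atom attached to the ring also changes from nitrogen to oxygen. A hydroxy group or an unsubstituted amine at the same spot would help separate these two differences, and a longer chain such as ethoxy would show whether the weaker result extends beyond methoxy.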